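Removing a Chloro Group: Expected Effect on Cell Tolerance

The source may hold more compounds than are shown below. What is called first, only, known or untested is meant among the compounds shown, and "the series" means these compounds.

Compound 1 `Cc1cc2cc(C#N)ccc2c(C)c1Nc1nc(Cl)nc(Nc2ccc(C#N)cc2)n1`: 7500 nM
Compound 2 `N#Cc1ccc(Nc2nccc(Nc3ccc4cc(C#N)ccc4c3F)n2)cc1`: 45000 nM

Of the compounds shown here, two have been measured in an ADME assay on MT2 cells (Homo sapiens) for inhibition, read by MTT assay; a lower number here means that less compound is tolerated, a higher number that more compound is tolerated. Compound 1 gives 7500 nM, the lowest of the two numbers, so it is the less well tolerated of the pair. Its nearest neighbour, compound 2, gives 45000 nM in this assay, a higher number that lies beyond the usual scatter of repeated measurements. The two structures differ in several places at once, so no single change can be read from this pair.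

Compound 3 `Cc1cc2cc(C#N)ccc2c(C)c1Nc1ncnc(Nc2ccc(C#N)cc2)n1` has not yet been measured. It is compound 1 with one change: hydrogen in place of chloro on an aromatic carbon. Going by the values given here, no measured pair shows what hydrogen in place of chloro on an aromatic carbon does in this assay, so the expectation rests on compound 1 alone. A small shift toward a higher number is expected, not beyond the scatter. The expected step of a 1.6-fold higher number from compound 1 to compound 3 (0.20 log units; within the scatter) is therefore modest. Compound 3 is estimated to give 12000 nM in this assay, within a range from 4000 nM to 40000 nM.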

Compound 3, half-maximal cytotoxic concentration: 9500 nM
Compound 3: the middle estimate sits 1.3-fold (0.10 log units) above what was measured; measured number inside the range.
By their numbers in this assay, from the lowest: compounds 1 and 3 (each within the scatter of the next); then compound 2.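

In this assay, putting hydrogen in place of chloro on the aromatic carbon between two ring nitrogen atoms gives a 1.3-fold higher number from compound 1 to compound 3 (0.10 log units; within the scatter). Going by these compounds alone, this is the first comparison here in which only one place differs, and it shows that the chloro group at this position can be taken away without a difference that can be told from the ordinary spread of repeat measurements. For this one pair, then, the number in this cell test does not depend on the chloro group being there, and the information at hand offers no measured explanation for this result.

What the compounds shown leave open is how other groups would read at the same position, for example an amine or a methoxy group, either of which might or might not give a step beyond the scatter. A single pair also cannot say whether swapping chloro for hydrogen would give a similarly small step on a different core, or with other groups in place of the 4-cyanophenylamino group.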